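This account rests on a few compounds, and the source may have more. Where it says the series, first, only, none or still open, it means among the compounds named here.

Compound 1 `COc1ccc2c(c1)C(n1ccccc1=O)=CC(C)(C)O2` gives 6.55 in a functional assay (aorta) with Rattus norvegicus as the target; a higher number here means a more potent compound, by a factor of ten per unit of this negative logarithm, a lower number a less potent compound.
Compound 2 `CC(=O)c1ccc2c(c1)C(n1ccccc1=O)=CC(C)(C)O2` gives 7.37 in this assay.
Compound 3 `CCC(=O)c1ccc2c(c1)C(n1ccccc1=O)=CC(C)(C)O2` gives 6.63 in this assay.

Compound 2 stands highest of the three in this assay; its nearest neighbour is compound 3, with a number 0.74 log units lower from compound 2 to compound 3 (beyond the scatter), and compound 1 lies further away, with a number 0.82 log units higher from compound 1 to compound 2 (beyond the scatter). The unmeasured compound 4 `CC1(C)C=C(n2ccccc2=O)c2cc(C(=O)c3ccccc3)ccc2O1` differs from compound 2 in one place: phenyl in place of methyl on a carbonyl carbon. For the measured compounds named here, two measured steps bear on this. The step of a number 0.74 log units lower from compound 2 to compound 3 (beyond the scatter) shows that a methyl in place of hydrogen on the chain carbon bound to the carbonyl already costs potency, and the step of a number 0.08 log units higher from compound 1 to compound 3 (within the scatter) shows that the propanoyl compound ends up near the methoxy compound. Phenyl enters where methyl leaves, a larger change than methyl for hydrogen, so a drop in this assay is expected, of a size at least comparable to that seen for compound 3. The expected step is a number 0.77 log units lower from compound 2 to compound 4 (beyond the scatter). Compound 4 is therefore estimated at 6.6, within a range from 5.9 to 7.3.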

Compound 4, logarithm of the reciprocal of the active concentration, log(1/C): 6.61
Estimate against measurement, compound 4: 0.01 log units below, and the stated range covers the measured number.
By their numbers in this assay, from the lowest: compounds 1, 4 and 3 (each within the scatter of the next); then compound 2.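

In this assay, phenyl in place of methyl on the carbonyl carbon gives a number 0.76 log units lower from compound 2 to compound 4 (beyond the scatter) and shows that the ring, like the ethyl of compound 3, does not keep the value of the acetyl compound. Phenyl in place of ethyl gives a number 0.02 log units lower from compound 3 to compound 4 (within the scatter) and benzoyl in place of methoxy gives a number 0.06 log units higher from compound 1 to compound 4 (within the scatter) and so, of the groups shown at this position, the acetyl of compound 2 alone stands apart, while ethyl and phenyl on the carbonyl carbon cannot be told apart. Nothing available here bears on the reason for this result.

The compounds shown leave open whether a formyl group or a carboxylic acid on this aromatic carbon would reach the level of compound 2 at 7.37 in this assay and whether an amine on the carbonyl carbon would do so. Going by these compounds, a longer chain or a substituted phenyl on the carbonyl carbon also remains open.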